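The source may report more compounds than this note shows. Statements on the series, on what has been measured and on what is new or still open speak of the compounds shown alone.

Measured compounds:
compound 1 `C=CCCCCCCc1cc2cn([C@H]3C[C@H](O)[C@@H](CO)O3)c(=O)nc2o1` — in a functional assay on HEL cells (Homo sapiens) for cytotoxicity, read by microscopy (on this read-out higher numbers stand for lower toxicity in this test and lower numbers for higher toxicity in this test), compound 1 reaches only the assay limit of > 200000 nM.
compound 2 `C#CCCCc1cc2cn([C@H]3C[C@H](O)[C@@H](CO)O3)c(=O)nc2o1` — in this assay compound 2 likewise reaches only the assay limit of > 200000 nM.

Among the compounds with values here, compound 2 therefore stands at a limit rather than at a measured number, and the one step measured so far, a step that the two limits leave unreadable from compound 1 to compound 2, cannot be read because both of its ends sit at that limit, as the limit of > 200000 nM in this assay, at which 2 of the 2 values shown sit, records. Compound 3 `C#CCCCCCCc1cc2cn([C@H]3C[C@H](O)[C@@H](CO)O3)c(=O)nc2o1` differs from compound 2 in one place: pent-4-yn-1-yl in place of ethynyl on a saturated chain carbon, three bonds along the chain from an aromatic carbon. Within the data shown here, the only step available bears on this change but gives no size, so there is no basis for expecting any movement in this assay beyond the scatter. Compound 3 is expected to give 200000 nM, within 100000 nM to 400000 nM. The expected step is a number no higher from compound 2 to compound 3 (the limit leaves the size open), most likely reported again as a limit.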

Compound 3, minimum cytotoxic concentration: > 200000 nM
Compound 3 ended at the assay's limit; the forecaster's own chance of this, stated with the estimate: 85%; the middle value lies on the limit itself.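

No step among compound 1, compound 2 and compound 3 can be read in this assay, since each of the three stands at a limit rather than at a measured number: the limit of > 200000 nM in this assay, at which 3 of the 3 values shown sit.

Going by these compounds, whether the chain or its end group makes any real difference to these compounds stays open.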